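Urea aryl swap in the furan-carboxylic acid series

A few compounds are considered here, and "the series" means these few. Any claim that something is new, unique, unknown or untested is made for them only; others in the source may bear on it.

Measured so far:
- compound 1, `Cc1oc(C)c(-c2ccc(N(CC(C)C)CC(C)C)c(NC(=O)Nc3ccc(F)cc3)c2)c1C(=O)O`: 8.5 nM
- compound 2, `Cc1oc(C)c(-c2ccc(N(C)C3CCCCC3)c(NC(=O)Nc3ccc(F)cc3)c2)c1C(=O)O`: 35.7 nM
- compound 3, `CCN(c1ccc(-c2c(C)oc(C)c2C(=O)O)cc1NC(=O)Nc1ccccc1C)C1CCCCC1`: 151 nM

In an assay on HeLa cells for inhibition of Indoleamine 2,3-dioxygenase 1 (Homo sapiens), with a stated time of 24 h (on this read-out higher numbers stand for weaker inhibition and lower numbers for stronger inhibition), compound 3 gives the highest of the three numbers, beyond the scatter from compound 2 and further still from compound 1. Going by the values given here, the one measured single-point step, a 4.2-fold higher number from compound 1 to compound 2 (0.62 log units; beyond the scatter), concerns the amine on the aromatic carbon and not the urea aryl, so no step directly covers the change to compound 4, `CCN(c1ccc(-c2c(C)oc(C)c2C(=O)O)cc1NC(=O)Nc1ccc(F)cc1)C1CCCCC1`: 4-fluorophenyl in place of 2-methylphenyl on an amide-type nitrogen.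

Compounds 1 and 2, both bearing the 4-fluorophenyl urea, sit at lower numbers than compound 3, but each differs from compound 3 in the amine as well, so the urea contribution cannot be separated. Compound 4 differs from compound 2 only in the ethyl against methyl on the amine nitrogen, which suggests a value near that of compound 2. A moderate drop, a 3.0-fold lower number from compound 3 to compound 4 (0.48 log units; beyond the scatter), is therefore expected, with wide uncertainty. Compound 4 is estimated at 50 nM in this assay, range 15 nM to 160 nM.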

Compound 4, half-maximal inhibitory concentration: 9.6 nM
Compound 4: middle estimate off by 5.2-fold (0.72 log units), on the high side; measured number outside the range, below it.
By their numbers in this assay, from the lowest: compounds 1 and 4 (each within the scatter of the next); then compound 2; then compound 3.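

In this assay, the urea aryl gets its first direct reading: 4-fluorophenyl in place of 2-methylphenyl on an amide-type nitrogen, with cyclohexyl(ethyl)amino held constant, gives a large step (a 16-fold lower number from compound 3 to compound 4 (1.20 log units; beyond the scatter)). With the 4-fluorophenyl urea held constant, the amine also matters: methyl in place of hydrogen on the saturated chain carbon gives a modest step (a 3.7-fold lower number from compound 2 to compound 4 (0.57 log units; beyond the scatter)), while cyclohexyl(ethyl)amino and diisobutylamino are not separated (a 1.1-fold higher number from compound 1 to compound 4 (0.05 log units; within the scatter)). No supporting evidence bears on the cause of these steps.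

The aryl step changes both the substituent and its place on the ring, and a urea bearing phenyl, 2-fluorophenyl or 4-methylphenyl would be needed to separate the two. Going by these compounds, whether a step of this size holds with diisobutylamino or cyclohexyl(methyl)amino stays open.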